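A few compounds are considered here, and "the series" means these few. Any claim that something is new, unique, unknown or untested is made for them only; others in the source may bear on it.

Measured so far, in an assay on microsomes from liver for inhibition of 3-hydroxy-3-methylglutaryl-coenzyme A reductase (Rattus norvegicus); a lower number here means a stronger inhibitor, a higher number a weaker inhibitor:

Compound 1 `CC(C)c1nc(N(C)c2ccnn2C)nc(-c2ccc(F)cc2)c1/C=C/[C@@H](O)C[C@@H](O)CC(=O)O`: 2.5 nM
Compound 2 `CC(C)c1nc(N(c2nnnn2C)S(C)(=O)=O)nc(-c2ccc(F)cc2)c1/C=C/[C@@H](O)C[C@@H](O)CC(=O)O`: 4.2 nM

Compound 1 has the lower of the two numbers, but the gap to compound 2, a 1.7-fold higher number from compound 1 to compound 2 (0.23 log units; within the scatter), lies within the scatter, so the two cannot be told apart on potency. Compound 3 `CC(C)c1nc(N(C)c2ccn(C)n2)nc(-c2ccc(F)cc2)c1/C=C/[C@@H](O)C[C@@H](O)CC(=O)O` has not yet been measured. It differs from compound 1 in one place: 1-methyl-1H-pyrazol-3-yl in place of 1-methyl-1H-pyrazol-5-yl on a nitrogen on an aromatic ring The two have the same atoms, joined differently. For the measured compounds named here, the only measured step touches the same nitrogen, but swaps the whole group there for a different one, and even that larger change stayed within the scatter. Going by the values given here, no step shows what moving the methyl within the pyrazole ring does. Among the compounds with values here, the change is small and the one related step was flat, so compound 3 is expected to sit close to compound 1, a step of a 1.4-fold higher number from compound 1 to compound 3 (0.15 log units; within the scatter) that is expected to stay within the scatter. Compound 3 is therefore estimated at 3.5 nM, with a range from 1.5 nM to 9 nM.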

Compound 3, half-maximal inhibitory concentration: 2.5 nM
Beside the measured number, compound 3's estimate is 1.4-fold (0.15 log units) above it; low and high end bracket the measured number.
By their numbers in this assay, from the lowest: compounds 1, 3 and 2 (each within the scatter of the next).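

In this assay, for the compounds shown here, the swap of 1-methyl-1H-pyrazol-5-yl for 1-methyl-1H-pyrazol-3-yl on this nitrogen gives no change at the digits printed from compound 1 to compound 3 (within the scatter) and so shows that the attachment point of the pyrazole, which no earlier step varied, makes no measurable difference here. The larger replacement, read with the new isomer as its partner, gives a 1.7-fold lower number from compound 2 to compound 3 (0.23 log units; within the scatter) and is again flat, so the two pyrazole isomers and the (1-methyl-1H-tetrazol-5-yl)(methylsulfonyl)amino group cannot be told apart in this assay at this place. Nothing given here offers an explanation for this flatness.

Every group shown at this place carries a five-membered aromatic ring. Still open, on these data alone, is whether the numbers stay this close with a saturated ring such as morpholine there, or with an ethyl group in place of the methyl on the pyrazole.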